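From Fluoro to Bromo: One Halogen Swap, One Expectation

The source may hold more compounds than are shown below. What is called first, only, known or untested is meant among the compounds shown, and "the series" means these compounds.

Of the compounds shown here, three sharing one core have been tested in a functional assay on MDA-MB-231 cells (Homo sapiens) for cytotoxicity, read by MTT assay, with a stated time of 72 h; on this read-out lower numbers stand for stronger inhibition and higher numbers for weaker inhibition. Compound 1 `COc1cc2c(Oc3ccc(NC(=O)c4nn(-c5cccc(F)c5)c(=O)c5ccccc45)cc3F)ccnc2cc1OCCCN1CCCC1` gives 880 nM in this assay. Compound 2 `COc1cc2c(Oc3ccc(NC(=O)c4nn(-c5ccccc5)c(=O)c5ccccc45)cc3F)ccnc2cc1OCCCN1CCN(C)CC1` gives 1580 nM. Compound 3 `COc1cc2c(Oc3ccc(NC(=O)c4nn(-c5ccc(F)cc5)c(=O)c5ccccc45)cc3F)ccnc2cc1OCCCN1CCN(C)CC1` gives 460 nM. Compound 3 thus holds the low end of the three numbers, with compound 1 within the usual scatter of it and compound 2 beyond it. Among the measured compounds shown here, the one single-point step recorded, a 3.4-fold lower number from compound 2 to compound 3 (0.54 log units; beyond the scatter), is a modest change that comes from adding a fluoro to an aromatic carbon.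

Compound 4 `COc1cc2c(Oc3ccc(NC(=O)c4nn(-c5ccc(Br)cc5)c(=O)c5ccccc45)cc3F)ccnc2cc1OCCCN1CCN(C)CC1` differs from compound 3 by bromo in place of fluoro on an aromatic carbon. For the measured compounds named here, no measured step swaps one halogen for another, so the only bearing comes from the fluoro-for-hydrogen step above, which shows that this position tolerates a halogen without loss. A change of one halogen for another at the same carbon is expected to move the number little, so compound 4 is estimated at 520 nM in this assay, between 200 nM and 1400 nM. That estimate corresponds to an expected step of a 1.1-fold higher number from compound 3 to compound 4 (0.05 log units; within the scatter), which is within the scatter.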

Compound 4, half-maximal inhibitory concentration: 1370 nM
The estimate for compound 4 lay 2.6-fold (0.42 log units) below the measured number, within the range that was stated.
By their numbers in this assay, from the lowest: compounds 3, 1, 4 and 2 (each within the scatter of the next, the first and the last beyond it).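

At this carbon, para to a large group, the choice of halogen matters in this assay: bromo in place of fluoro gives a 3.0-fold higher number from compound 3 to compound 4 (0.47 log units; beyond the scatter). Bromo in place of hydrogen gives a 1.2-fold lower number from compound 2 to compound 4 (0.06 log units; within the scatter), so the gain seen with fluoro does not carry over to bromo, and a halogen at this carbon cannot be treated as interchangeable with another. Nothing available here explains why the two halogens part ways.

The compounds shown leave open how other groups on this same carbon would read, such as chloro, methoxy or an amine. They also leave open whether the swap from 4-fluorophenyl to 4-bromophenyl would give a step of similar size on a compound carrying the side chain of compound 1.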